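Halogenated anilines on a shared core: cytotoxicity notes

The compounds below may be only part of what the source reports. "The series", "measured", "known", "first", "only" and "open" are said of these compounds alone.

In a functional assay on MDA-MB-231 cells (Homo sapiens) for cytotoxicity, read by MTT assay, with a stated time of 72 h (a higher number here means a weaker inhibitor, a lower number a stronger inhibitor), compound 1 `CCCCCCNc1nc(SCc2ccc(C(F)(F)F)cc2)nc2ccccc12` gives 20200 nM.
In this assay compound 2 `FC(F)(F)c1ccc(CSc2nc(Nc3ccccc3)c3ccccc3n2)cc1` gives 18400 nM.
Compound 3 `COc1ccccc1Nc1nc(SCc2ccc(C(F)(F)F)cc2)nc2ccccc12` reaches only the limit of this assay, > 50000 nM.

Compound 2 holds the lowest of the two numbers, with compound 1 nearest at a 1.1-fold lower number from compound 1 to compound 2 (0.04 log units; within the scatter). Compound 4 `Fc1ccc(Nc2nc(SCc3ccc(C(F)(F)F)cc3)nc3ccccc23)cc1Cl` differs from compound 2 by 3-chloro-4-fluorophenyl in place of phenyl on a nitrogen on an aromatic ring. Within the data shown here, the only measured step that alters the phenyl on this nitrogen is an at least 2.7-fold higher number from compound 2 to compound 3 (0.43 log units; beyond the scatter), and it went to the limit (the limit of > 50000 nM in this assay, at which 1 of the 3 values shown sits); the other step, an at least 2.4-fold higher number from compound 1 to compound 3 (0.39 log units; beyond the scatter), points the same way. Substituting the phenyl has so far weakened the series, so compound 4 is expected to show a small weakening, a 1.5-fold higher number from compound 2 to compound 4 (0.18 log units; within the scatter), with some chance of a limit. Compound 4 is estimated at 28000 nM, between 11000 nM and 60000 nM.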

Compound 4, half-maximal inhibitory concentration: 14500 nM
Estimate against measurement, compound 4: 1.9-fold (0.29 log units) above; low and high end bracket the measured number.
By their numbers in this assay, from the lowest: compounds 4, 2 and 1 (each within the scatter of the next). At a limit, above all of these: compound 3.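

On this nitrogen, substitution of the phenyl need not cost activity in this assay: 3-chloro-4-fluorophenyl leaves compound 4 level with the anilino compound (a 1.3-fold lower number from compound 2 to compound 4 (0.10 log units; within the scatter)) and with the hexyl compound (a 1.4-fold lower number from compound 1 to compound 4 (0.14 log units; within the scatter)). Only the change from 2-methoxyphenyl separates (an at least 3.4-fold lower number from compound 3 to compound 4 (0.53 log units; beyond the scatter)), so the weakening seen earlier does not extend to every substituted phenyl. That step is a bound, not a measured size, as compound 3 stands at a limit: the limit of > 50000 nM in this assay, at which 1 of the 4 values shown sits.

Open, on these data alone, is whether chlorine or fluorine alone gives the same reading. Also open, as far as these compounds go, is whether a phenyl carrying an amine or a carboxylic acid stays level with compound 2 or moves toward compound 3.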